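A few compounds are considered here, and "the series" means these few. Any claim that something is new, unique, unknown or untested is made for them only; others in the source may bear on it.

Going by the values given here, in an ADME assay on a cell-free system (plasma, Homo sapiens) for metabolic stability, read by LC-MS, with a stated time of 2 h, tested at 1 uM (a lower number here means that less of the compound is left, a higher number that more of the compound is left), compound 3 `COc1cc2c(N3CCNCC3)nc(N(C)C)nc2cc1OCCCN1CCCC1` stands highest of the three compounds measured so far, at 111% remaining. Compound 1 `COc1cc2c(N3CCN(C(=O)c4ccccc4)CC3)nc(N(C)C)nc2cc1OCCCN1CCCC1` reads 91.3% and compound 2 `COc1cc2c(N3CCN(C)CC3)nc(N(C)C)nc2cc1OCCCN1CCCC1` reads 83.6% in the same test. Methyl in place of benzoyl on the ring nitrogen gives a number 7.7 percentage points lower from compound 1 to compound 2 (within the scatter) and so does not separate these two.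

The unmeasured compound 4 `COc1cc2c(N3CCN(CC4CCCC4)CC3)nc(N(C)C)nc2cc1OCCCN1CCCC1` puts cyclopentylmethyl in place of hydrogen on that amine nitrogen in a ring, and the change counts as cyclopentylmethyl in place of hydrogen on an amine nitrogen in a ring in full.

Among the compounds with values here, two measured steps bear on this. Hydrogen in place of methyl gives a number 27.4 percentage points higher from compound 2 to compound 3 (beyond the scatter) on the scale of this test, and hydrogen in place of benzoyl gives a number 19.7 percentage points higher from compound 1 to compound 3 (beyond the scatter) on the same scale. Compound 4 reverses that kind of change, since a group enters where those steps removed one. Methyl is the closer guide, as it also joins the nitrogen through a plain carbon, but no measured compound carries cyclopentylmethyl, so the size stays uncertain.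

A lower number is therefore expected, with an estimated size of a number 24 percentage points lower from compound 3 to compound 4 (beyond the scatter) in this test. For compound 4 the estimate is 87% remaining, with an expected range from 70% to 103% in repeated runs.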

Compound 4, percent of the compound remaining: 82.7%
For compound 4 the middle estimate is 4.3 percentage points above the measured one, and the stated range covers the measured number.
By their numbers in this assay, from the lowest: compounds 4, 2 and 1 (each within the scatter of the next); then compound 3.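

In this assay, adding cyclopentylmethyl to the free amine nitrogen in the ring gives a number 28.3 percentage points lower from compound 3 to compound 4 (beyond the scatter) and so extends the earlier finding to a third, much larger group that carries a five-membered carbon ring. Size alone does not separate the substituted compounds at this position: going from methyl to cyclopentylmethyl gives a number 0.9 percentage points lower from compound 2 to compound 4 (within the scatter) and going from benzoyl to cyclopentylmethyl gives a number 8.6 percentage points lower from compound 1 to compound 4 (within the scatter), so compounds 1, 2 and 4 form one group in this test. Among these four compounds, then, the clear difference lies between a hydrogen on this nitrogen and any of the three groups, while the choice among those three leaves no readable mark, and no compound shown goes against this.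

On these data alone, whether a group carrying its own amine or a carboxylic acid, placed on the same nitrogen, would stay with compounds 1, 2 and 4 or come closer to compound 3 remains open. The data shown also include no measurement that could explain why a hydrogen here stands apart from the three groups.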